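Swapping Ethylsulfanyl for Sec-butoxy on the Carbonyl Carbon

The source may hold more compounds than are shown below. What is called first, only, known or untested is meant among the compounds shown, and "the series" means these compounds.

For the measured compounds named here, compound 2 `CCSC(=O)C1=C(C)NC(=O)NC1c1ccoc1` is the lower of the two compounds measured so far. In an assay on membranes from HeLa cells for displacement of a labelled ligand from adenosine receptor A3 (Homo sapiens), read by scintillation counting, with a stated time of 180 min, tested at 1 uM (on this read-out lower numbers stand for less inhibition and higher numbers for more inhibition at the one concentration tested (going by the name of the read-out)), compound 2 gives 1%, while compound 1 `CC1=C(C(=O)CC(C)C)C(c2ccoc2)NC(=O)N1` gives 18%. Going by the values given here, the single measured step, a number 17 percentage points lower from compound 1 to compound 2 (beyond the scatter), was a change at the same carbonyl carbon, ethylsulfanyl in place of isobutyl, and it lay beyond the scatter, so substituents on this carbonyl carbon do move the read-out. Compound 3 `CCC(C)OC(=O)C1=C(C)NC(=O)NC1c1ccoc1` has not yet been measured; it differs from compound 2 by sec-butoxy in place of ethylsulfanyl on a carbonyl carbon. Among the compounds with values here, no measured step compares ethylsulfanyl with sec-butoxy, so the direction of this change cannot be read from the data. The step of a number 7 percentage points higher from compound 2 to compound 3 (within the scatter) is therefore expected to be small, likely within the scatter, with a slight lean upward given how low compound 2 sits. The estimate for compound 3 is 8%, with a range from -5% to 25%.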

Compound 3, a percentage reported as inhibition, at one concentration (the size of the read-out at that concentration, not a potency): 11%
The estimate for compound 3 lay 3 percentage points below the measured number; the measured number falls inside the stated range.
By their numbers in this assay, from the lowest: compounds 2, 3 and 1 (each within the scatter of the next, the first and the last beyond it).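

In this assay, the step of a number 10 percentage points higher from compound 2 to compound 3 (within the scatter) means that sec-butoxy and ethylsulfanyl on this carbonyl carbon cannot be told apart, although the entering group carries more heavy atoms and has oxygen where the leaving group has sulfur. The step of a number 7 percentage points lower from compound 1 to compound 3 (within the scatter) also stays within the scatter, so sec-butoxy cannot be told apart from isobutyl here either, and compound 3 is separated from neither neighbour, even though compound 1 and compound 2 are separated beyond the scatter. Nothing available explains these results.

From the compounds shown here alone, what remains open is whether any group on this carbonyl carbon gives a number clearly beyond that of compound 1. An amine or a longer chain in place of sec-butoxy could test this, and the compounds shown give no direction for either.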